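A few compounds are considered here, and "the series" means these few. Any claim that something is new, unique, unknown or untested is made for them only; others in the source may bear on it.

Measured so far:
- compound 1 `CC1(C)C=C(n2ccccc2=O)c2cc(S(=O)(=O)N=[N+]=[N-])ccc2O1`: 16.2 nM
- compound 2 `CNS(=O)(=O)c1ccc2c(c1)C(n1ccccc1=O)=CC(C)(C)O2`: 17.8 nM
- compound 3 `CC1(C)C=C(n2ccccc2=O)c2cc(S(=O)(=O)Nc3ccc([N+](=O)[O-])cc3)ccc2O1`: 2090 nM

All three were tested in a functional assay with Rattus norvegicus as the target; on this read-out lower numbers stand for an effect already at smaller amounts and higher numbers for an effect only at larger amounts of compound. Compound 1 stands at the low end of these numbers, although the difference to compound 2, a 1.1-fold higher number from compound 1 to compound 2 (0.04 log units; within the scatter), is within the scatter, whereas compound 3 lies far apart, as a 130-fold higher number from compound 1 to compound 3 (2.11 log units; beyond the scatter) shows.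

Compound 4 `CC1(C)C=C(n2ccccc2=O)c2cc(S(=O)(=O)NC(=O)Nc3ccccc3)ccc2O1` has not yet been measured. It differs from compound 1 in one place: (phenylcarbamoyl)amino in place of azido on a sulfonyl sulfur. Two kinds of measured step bear on this change. Putting a small methylamino group in place of the azido group gave a 1.1-fold higher number from compound 1 to compound 2 (0.04 log units; within the scatter), while putting a (4-nitrophenyl)amino group there gave a 130-fold higher number from compound 1 to compound 3 (2.11 log units; beyond the scatter), and the same contrast appears in a 120-fold higher number from compound 2 to compound 3 (2.07 log units; beyond the scatter). Among the compounds with values here, the entering (phenylcarbamoyl)amino group, like (4-nitrophenyl)amino, brings a six-membered aromatic ring of carbon only, so a step toward a higher number is expected, a 19-fold higher number from compound 1 to compound 4 (1.27 log units; beyond the scatter), though no measured pair contains this exact group, which leaves the size uncertain. Compound 4 is therefore estimated at 300 nM, with a likely range from 40 nM to 2500 nM.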

Compound 4, half-maximal effective concentration: 1410 nM
Estimate against measurement, compound 4: 4.7-fold (0.67 log units) below; the measured number falls inside the stated range.
By their numbers in this assay, from the lowest: compounds 1 and 2 (each within the scatter of the next); then compounds 4 and 3 (each within the scatter of the next).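

In this assay, the change from azido to (phenylcarbamoyl)amino on the sulfonyl sulfur gives an 87-fold higher number from compound 1 to compound 4 (1.94 log units; beyond the scatter), and phenylcarbamoyl in place of methyl on the sulfonamide nitrogen gives a 79-fold higher number from compound 2 to compound 4 (1.90 log units; beyond the scatter). The high numbers therefore no longer belong to compound 3 alone, so among these four compounds both groups with a six-membered aromatic ring of carbon only go with high numbers, and none goes against this. Exchanging one such group for the other gives a 1.5-fold lower number from compound 3 to compound 4 (0.17 log units; within the scatter), which stays within the scatter, so these two different groups cannot be told apart here.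

A hexylamino chain or a cyclohexylamino group on the sulfonyl sulfur would help show whether the aromatic ring or simply a larger group goes with the high numbers. The data shown offer no measurement that explains these steps.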